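A Nitro Group Added to a Guanidine Sigma Ligand

The compounds below may be only part of what the source reports. "The series", "measured", "known", "first", "only" and "open" are said of these compounds alone.

Three guanidines have been measured in an assay on membranes from brain (Cavia porcellus) for binding affinity to Sigma non-opioid intracellular receptor 1 (Homo sapiens); a higher number here means a weaker inhibitor, a lower number a stronger inhibitor. Compound 1, `Cc1ccccc1/N=C(/N)Nc1cccc(O)c1`, gives 155 nM in this assay, the second highest of the three numbers. Compound 3, `Cc1cc(Br)ccc1NC(=N)Nc1ccc(Br)cc1C`, carrying two bromine atoms on its outer rings, gives 32 nM, and compound 2, `CCCCNC(=N)NCCCC`, built from two butyl chains without any ring, gives 800 nM. The value of compound 1 differs from that of compound 3 beyond the usual scatter, and likewise from that of compound 2, so compound 1 stands clearly between the other two.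

Compound 4, `Cc1cc([N+](=O)[O-])ccc1/N=C(/N)Nc1cccc(O)c1`, differs from compound 1 in a single place: nitro in place of hydrogen on an aromatic carbon. Among the measured compounds shown here, no measured pair here shows this same exchange, so the size of the step rests on judgement alone. Compound 3 shows that a substituent at this position on the outer ring is compatible with tight binding, but it also carries other changes, so no clean lesson can be drawn. A modest step, or none beyond the scatter, is expected from compound 1 to compound 4, a 1.2-fold lower number from compound 1 to compound 4 (0.08 log units; within the scatter). Compound 4 is therefore estimated at 130 nM, with a plausible range from 45 nM to 400 nM.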

Compound 4, half-maximal inhibitory concentration: 94 nM
Beside the measured number, compound 4's estimate is 1.4-fold (0.14 log units) above it; measured number inside the range.
By their numbers in this assay, from the lowest: compound 3; then compounds 4 and 1 (each within the scatter of the next); then compound 2.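

In this assay, putting nitro in place of hydrogen on an aromatic carbon gives a 1.6-fold lower number from compound 1 to compound 4 (0.22 log units; within the scatter). Among the compounds shown here, this is the first direct reading for this position, para to a large group and meta to a methyl group: a sizeable group with no ring can enter here without a step beyond the scatter, something compound 3 could only hint at since it carries other changes as well. No other measurement here bears on what lies behind this result.

Going by these compounds, whether a very different group in the same place, such as an amine or a carboxylic acid, would also leave the number within the scatter remains open. A single exchange on a single core also cannot show whether nitro would behave the same way on another guanidine.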